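The source may hold more compounds than are shown below. What is called first, only, known or untested is meant among the compounds shown, and "the series" means these compounds.

The compounds share the core of compound 1 `O=C(Nc1ccc(F)cc1)N[C@@H]1C2CCN(CC2)[C@@H]1Cc1cccnc1`. In an assay on a protein complex for binding affinity to Neuronal acetylcholine receptor; alpha4/beta2 (Homo sapiens) (on this read-out higher numbers stand for weaker inhibition and lower numbers for stronger inhibition), compound 1 reaches only the assay limit of > 10000 nM. Compound 2 `O=C(NCc1ccc(Br)cc1)N[C@@H]1C2CCN(CC2)[C@@H]1Cc1cccnc1` carries 4-bromobenzyl in place of 4-fluorophenyl on an amide-type nitrogen. In this assay compound 2 likewise stops at the limit of > 10000 nM. The step that the two limits leave unreadable from compound 1 to compound 2 stays unreadable because of the limit of > 10000 nM in this assay, at which 2 of the 2 values shown sit. Compound 2 therefore stands at a limit, with no measured number inside the range of this assay. Compound 3 `C/C(=C\c1ccccc1)C(=O)N[C@@H]1C2CCN(CC2)[C@@H]1Cc1cccnc1` differs from compound 2 by 1-methyl-2-phenylethenyl in place of (4-bromobenzyl)amino on a carbonyl carbon. Going by the values given here, the single measured step bears on this change only by being unreadable, so no measured step speaks for or against a gain. The expectation is thus for a step that the limit leaves unreadable from compound 2 to compound 3 that does not clearly leave the region of the limit. Compound 3 is estimated at 15000 nM in this assay, between 2000 nM and 100000 nM.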

Compound 3, inhibition constant: > 10000 nM
Compound 3 was reported as a limit (the forecaster's own chance of this, stated with the estimate: 70%); the middle value lies beyond the limit too.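

No new step can be read: the steps from compound 1 and compound 2 to compound 3 stay unreadable because all three compounds stop at one assay limit: the limit of > 10000 nM in this assay, at which 3 of the 3 values shown sit.

The compounds shown leave open which group on the carbonyl carbon, if any, would give a measured value within the range of this assay.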